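Methoxy in Place of Nitro on Two Related Cores

The source may hold more compounds than are shown below. What is called first, only, known or untested is meant among the compounds shown, and "the series" means these compounds.

Compound 1, `O=C(Cn1cc(-c2cccc([N+](=O)[O-])c2)nn1)NCc1ccccc1`, carries a nitro group on its aromatic ring. In an ADME assay on cells (spleen, Mus musculus, strain C57BL/6) for inhibition, read by flow cytometry and propidium iodide staining, with a stated time of 24 h, at 37 degrees C (on this read-out lower numbers stand for an effect already at smaller amounts and higher numbers for an effect only at larger amounts of compound), compound 1 gives > 2000 uM, which is a limit of the assay and not a number. Compound 2, `COc1cccc(-c2cn(CC(=O)NCc3ccccc3)nn2)c1`, differs from compound 1 in one place: methoxy in place of nitro on an aromatic carbon. In this assay compound 2 gives 840 uM. The step of an at least 2.3-fold lower number from compound 1 to compound 2 (0.37 log units; beyond the scatter) is thus the one measured effect of this change, and its true size is open at one end, since one of the three values shown is the limit of > 2000 uM in this assay, at which 1 of the 3 values shown sits.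

Compound 3, `O=C(Cn1nncc1-c1cccc([N+](=O)[O-])c1)NCc1ccccc1`, is built from the same atoms as compound 1, joined differently; how the two cores differ is not broken down here. In this assay compound 3 is reported as "non-toxic" (no number reported), with no number attached. Compound 4, `COc1cccc(-c2cnnn2CC(=O)NCc2ccccc2)c1`, has not been measured. It differs from compound 3 by methoxy in place of nitro on an aromatic carbon, the same change that turns compound 1 into compound 2, made on the other core.

For the measured compounds named here, the expectation for compound 4 rests on compound 2, whose value 840 uM is the only number that the change has produced, and on the step of an at least 2.3-fold lower number from compound 1 to compound 2 (0.37 log units; beyond the scatter) that led to it. Compound 4 is therefore expected to fall near 1000 uM in this assay, estimated between 400 uM and 2500 uM. Whether a number rather than a limit will be reported is itself uncertain.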

Compound 4, concentration for half-maximal effect: > 2000 uM
Compound 4 gave a limit, no number (the forecaster's own chance of this, stated with the estimate: 40%); at least 2.0-fold (0.30 log units) between middle value and limit.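

In this assay compound 4 gives > 2000 uM, which is a limit of the assay and not a number. For the compounds shown here, compound 3 carries no number either, so no step from compound 3 to compound 4 can be read. The compounds shown leave open how large the effect of methoxy in place of nitro is on either core, and the comparison runs up against one limit: the limit of > 2000 uM in this assay, at which 2 of the 4 values shown sit.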